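Swapping the Ester Tail on a Shared Core

The compounds below may be only part of what the source reports. "The series", "measured", "known", "first", "only" and "open" are said of these compounds alone.

Two compounds of a shared core have been examined in an ADME assay on HepG2 2.2.15 cells (Homo sapiens) for cytotoxicity; on this read-out higher numbers stand for lower toxicity in this test and lower numbers for higher toxicity in this test. Compound 1 `O=c1c(CCO)c(-c2ccccc2Cl)c2cc(Cl)ccc2n1-c1ccccc1` gives 26000 nM. Compound 2 `CC(=O)NCC(=O)OCCc1c(-c2ccccc2Cl)c2cc(Cl)ccc2[nH]c1=O` gives 110000 nM, the higher of the two numbers, and its separation from compound 1 lies beyond the scatter. Compound 3 `COc1cccc(/C=C/C(=O)OCCc2c(-c3ccccc3Cl)c3cc(Cl)ccc3[nH]c2=O)c1` has not yet been measured in this assay. It differs from compound 2 in one place (2-(3-methoxyphenyl)ethenyl in place of acetamidomethyl on a carbonyl carbon), a change on a carbonyl carbon whose other neighbours are an oxygen next to a carbonyl group. For the measured compounds named here, no step between measured compounds describes such a change, so the expectation rests on compound 2 alone. A moderate downward step a 2.4-fold lower number from compound 2 to compound 3 (0.39 log units; beyond the scatter) is expected, one that would not lie far beyond the scatter. For compound 3 the estimated value in this assay is 45000 nM, with a range from 15000 nM to 130000 nM.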

Compound 3, half-maximal cytotoxic concentration: > 1300000 nM
Compound 3: no number, only a limit; the forecaster's own chance of this, stated with the estimate: 20%; middle value at least 28-fold (1.46 log units) away from the limit.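

The ester tail of the shared core proves able to shift this read-out strongly: putting 2-(3-methoxyphenyl)ethenyl in place of acetamidomethyl on a carbonyl carbon gives an at least 11-fold higher number from compound 2 to compound 3 (1.07 log units; beyond the scatter), a large step towards lower toxicity in this assay. Compound 3 reads > 1300000 nM, which is a limit of the assay and not a number. The step therefore marks only the least that this change can amount to, and its full size remains unknown: the limit of > 1300000 nM in this assay, at which 1 of the 3 values shown sits.

For the compounds shown here, the single step does not separate the share of the aromatic ring, the methoxy group and the ethenyl double bond in this change. On these data alone, how a tail carrying an amine or a carboxylic acid, or a plain saturated chain, would read in this assay also stays open.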